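The source may hold more compounds than are shown below. What is called first, only, known or untested is meant among the compounds shown, and "the series" means these compounds.

Compound 1 `COc1ccc(-c2nc3sc(-c4ccccc4)cn3n2)cc1`: 38%
Compound 2 `Clc1ccc(-c2cn3nc(-c4ccccc4)nc3s2)cc1`: 40%

In a functional assay on UO-31 cells (Homo sapiens) for inhibition, read by sulforhodamine B assay, with a stated time of 48 h, tested at 10 uM (a lower number here means less inhibition of growth, a higher number more inhibition of growth at the concentration tested), compound 2 gives 40%. This lies within the scatter of compound 1 at 38%, so the two compounds cannot be told apart on these numbers.

Compound 3 `COc1ccc(-c2nc3sc(-c4ccc(Cl)cc4)cn3n2)cc1` differs from compound 2 by one change: methoxy in place of hydrogen on an aromatic carbon, para to a large group (methoxy in place of hydrogen on an aromatic carbon). It therefore carries both the methoxy of compound 1 and the chlorine of compound 2. Going by the values given here, no measured pair isolates this change, so its effect has not been seen directly. Compound 1 already bears a methoxy and gives 38%, which offers no sign of a large shift. The expected change, a number 2 percentage points higher from compound 2 to compound 3 (within the scatter), is small, slightly upward and not beyond the scatter. In this assay, the estimated value for compound 3 is 42%, with an expected range from 25% to 60%.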

Compound 3, percent growth inhibition at one concentration: -7.46%
For compound 3 the middle estimate is 49.5 percentage points above the measured one, outside the stated range (below it).
By their numbers in this assay, from the lowest: compound 3; then compounds 1 and 2 (each within the scatter of the next).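

Putting methoxy in place of hydrogen on an aromatic carbon, para to a large group, brings a number 47.5 percentage points lower from compound 2 to compound 3 (beyond the scatter) in this assay, and chloro in place of hydrogen on an aromatic carbon brings a number 45.5 percentage points lower from compound 1 to compound 3 (beyond the scatter). Compound 3 gives -7.46%, so no inhibition of growth is seen at the concentration tested. Going by these compounds alone, the effect of each group therefore depends on the other: together in compound 3, they do not keep the inhibition seen with compound 1 or compound 2, which the earlier compounds alone could not reveal.

From the compounds shown here alone, it remains open whether an amine, a carboxylic acid or a longer chain at the methoxy position would restore inhibition while the chlorine stays in place. No measurement shown here explains why the two groups behave this way together.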